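Adding a hydroxy group to compound 2

The source may report more compounds than this note shows. Statements on the series, on what has been measured and on what is new or still open speak of the compounds shown alone.

compound 1 `O=C1/C(=C\c2ccncc2)C(c2ccccc2)Oc2ccccc21` gives 4600 nM
compound 2 `O=C1/C(=C\c2ccccc2)C(c2ccccc2)Oc2ccccc21` gives 52600 nM
compound 3 `O=C1/C(=C/c2ccccc2)C(c2ccccc2)Oc2ccccc21` gives 59400 nM

These values come from a functional assay on WM-115 cells (Homo sapiens) for cytotoxicity, read by MTT assay, with a stated time of 46 h (on this read-out higher numbers stand for weaker inhibition and lower numbers for stronger inhibition), and place compound 2 at the weak end of this small set, level with its double-bond isomer. That gap is a 1.1-fold higher number from compound 2 to compound 3 (0.05 log units; within the scatter) and shows no real difference. The only large gap is an 11-fold higher number from compound 1 to compound 2 (1.06 log units; beyond the scatter) when phenyl replaces pyridin-4-yl.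

Compound 4 `O=C1/C(=C\c2ccccc2)C(c2ccccc2)Oc2ccc(O)cc21` changes a different part of the molecule: hydroxy in place of hydrogen on an aromatic carbon on the shared core. Neither measured step involves this hydroxy group, so neither can predict its effect directly. Among the measured compounds shown here, the phenyl step shows only that one local change can shift the number substantially. A modest move towards stronger inhibition is a tentative expectation, and a result within the scatter would be no surprise. The estimated change in this assay is a 1.9-fold lower number from compound 2 to compound 4 (0.27 log units; within the scatter) as a best guess. Compound 4 is expected at 28000 nM with an estimated range from 8000 nM to 80000 nM.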

Compound 4, half-maximal inhibitory concentration: 9100 nM
For compound 4 the middle estimate is 3.1-fold (0.49 log units) above the measured one; low and high end bracket the measured number.
By their numbers in this assay, from the lowest: compounds 1 and 4 (each within the scatter of the next); then compounds 2 and 3 (each within the scatter of the next).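

In this assay, among the compounds shown here, the earlier compounds showed changes only at the group on the double-bonded chain carbon and in the geometry of the double bond, whereas hydroxy in place of hydrogen on an aromatic carbon of the shared core gives a 5.8-fold lower number from compound 2 to compound 4 (0.76 log units; beyond the scatter) and so shows that this part of the molecule also affects the number. A single added heavy atom is enough for a step beyond the scatter. Nothing measured here explains why this step has the size it has.

The compounds shown leave open whether a methoxy group, an amine or a fluorine atom at the same place would give a similar number. They also leave open whether the hydroxy group would give a similar step on compound 1 or compound 3.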